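Tert-butyl Replacing 1,2,2-Trimethylpropyl on Compound 2

The compounds below may be only part of what the source reports. "The series", "measured", "known", "first", "only" and "open" are said of these compounds alone.

Within the data shown here, compound 2 `C[C@@H](/N=c1\c(O)c(O)\c1=N/Cc1ccc(C#N)cc1)C(C)(C)C` gives 270 nM in a functional assay for inhibition, with Rattus norvegicus as the target (a lower number here means a stronger inhibitor, a higher number a weaker inhibitor), the lowest of the three numbers known. Compound 3 `CC(C)(C)/N=c1\c(O)c(O)\c1=N/Cc1ccc(F)cc1F` gives 2100 nM, and compound 1 `CC(/N=c1\c(O)c(O)\c1=N/[C@H](C)C(C)(C)C)c1ccc(C#N)cc1` gives 6500 nM. Among the measured compounds shown here, the one step measured, a 24-fold lower number from compound 1 to compound 2 (1.38 log units; beyond the scatter), concerns the carbon bearing the aryl group, not the position now changed. Compound 4 `CC(C)(C)/N=c1\c(O)c(O)\c1=N/Cc1ccc(C#N)cc1` differs from compound 2 by tert-butyl in place of 1,2,2-trimethylpropyl on a double-bonded nitrogen. For the measured compounds named here, no measured step bears directly on this change; compound 3 carries the tert-butyl but a different aryl group, so it offers only an indirect hint. A modest weakening is therefore expected, a 2.6-fold higher number from compound 2 to compound 4 (0.41 log units; beyond the scatter), with wide uncertainty. Compound 4 is estimated at 700 nM, between 200 nM and 2500 nM.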

Compound 4, half-maximal inhibitory concentration: 270 nM
Estimate against measurement, compound 4: 2.6-fold (0.41 log units) above, within the range that was stated.
By their numbers in this assay, from the lowest: compounds 2 and 4 (each within the scatter of the next); then compound 3; then compound 1.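

The step shows no change at the digits printed from compound 2 to compound 4 (within the scatter) in this assay when tert-butyl replaces 1,2,2-trimethylpropyl on a double-bonded nitrogen. Among these compounds, this is the first direct reading at this position: in this pair, neither the defined stereocentre nor the larger chain of compound 2 is needed to keep the number. No measurement at hand accounts for this result.

The compounds shown leave open how methyl or cyclohexyl would read on this nitrogen. They also leave open what the opposite stereocentre of the 1,2,2-trimethylpropyl group would give with the same nitrile-bearing aryl group.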